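Swapping 4-methoxyphenyl for 2-phenylethenyl on the shared core

The source may hold more compounds than are shown below. What is called first, only, known or untested is meant among the compounds shown, and "the series" means these compounds.

In a functional assay on U-87MG ATCC cells for inhibition, with U-87 MG (Homo sapiens) as the target, read by MTT assay, with a stated time of 48 h (on this read-out higher numbers stand for weaker inhibition and lower numbers for stronger inhibition), compound 1 `CCc1ccc(-c2nc3ccccn3c2Sc2ccccc2)cc1` gives 61700 nM. Compound 2 `COc1ccc(-c2nc3ccccn3c2Sc2ccccc2)cc1` gives > 100000 nM, and this is a limit of the assay, not a number. Compound 3 `C(=C/c1nc2ccccn2c1Sc1ccccc1)\c1ccccc1` carries 2-phenylethenyl in place of 4-methoxyphenyl on an aromatic carbon. For the measured compounds named here, only one measured step bears on this change, namely an at least 1.6-fold higher number from compound 1 to compound 2 (0.20 log units; that floor lies within the scatter), and it tells little, since it is open-ended. Compound 3 has no methoxy, and neither does compound 1 at 61700 nM, so a modest move toward lower numbers is expected in this assay, perhaps no larger than the scatter. The estimated change is an at least 1.6-fold lower number from compound 2 to compound 3 (0.22 log units; that floor lies within the scatter). For compound 3 the expected value is 60000 nM, with an estimated range of 20000 nM to 100000 nM.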

Compound 3, half-maximal inhibitory concentration: 59200 nM
Compound 3: the middle estimate sits 1.0-fold (0.01 log units) above what was measured, within the range that was stated.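

In this assay, for the compounds shown here, this place on the shared core had so far held only substituted phenyl groups, and the step to 2-phenylethenyl, with its double bond outside aromatic rings, is a 1.0-fold lower number from compound 1 to compound 3 (0.02 log units; within the scatter). Against the methoxy compound, the step is an at least 1.6-fold lower number from compound 2 to compound 3 (0.22 log units; that floor lies within the scatter). Compound 2 gives a limit of the assay and not a number, so that step has only a floor and its true size cannot be read: the limit of > 100000 nM in this assay, at which 1 of the 3 values shown sits.

The compounds shown leave open whether any group at this place can move the number beyond the scatter, for instance an amine or a carboxylic acid. Going by these compounds alone, they also leave open whether the double bond of 2-phenylethenyl matters, since no compound here carries a saturated two-carbon link in its place.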